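The source may hold more compounds than are shown below. What is called first, only, known or untested is meant among the compounds shown, and "the series" means these compounds.

Measured compounds:
compound 1 `S=C(SCc1cn(Cc2ccc(Cl)c(Cl)c2)nn1)N1CCNCC1` — "not determined" (no result reported) in a functional assay on MCF7 cells (Homo sapiens) for inhibition, read by MTT assay, with a stated time of 72 h; on this read-out lower numbers stand for stronger inhibition and higher numbers for weaker inhibition
compound 2 `CC(C)(C)OC(=O)N1CCN(C(=S)SCc2cn(Cc3cc(=O)oc4cc(O)ccc34)nn2)CC1` — 10400 nM
compound 3 `O=C(OCc1ccccc1)N1CCN(C(=S)SCc2cn(Cc3ccc(Cl)c(Cl)c3)nn2)CC1` — 10600 nM

Compound 3 gives the higher of the two numbers, yet its gap to compound 2 is within the scatter, so no order between the two can be read. Compound 1 is without a number.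

Compound 4 `O=C(OCc1ccccc1)N1CCN(C(=S)SCc2cn(Cc3ccccc3F)nn2)CC1` differs from compound 3 in one place: 2-fluorophenyl in place of 3,4-dichlorophenyl on a saturated chain carbon bound to an aromatic nitrogen. Going by the values given here, no measured pair shows this change, so there is no step to lean on. Among the compounds with values here, the series so far shows only weak inhibition, and the change is expected to leave the number near that of compound 3, with a step of a 1.2-fold higher number from compound 3 to compound 4 (0.09 log units; within the scatter) that stays within the scatter or drifts slightly toward weaker inhibition. Compound 4 is therefore estimated at 13000 nM, with a range from 5000 nM to 35000 nM.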

Compound 4, half-maximal inhibitory concentration: 7950 nM
For compound 4 the middle estimate is 1.6-fold (0.21 log units) above the measured one, within the range that was stated.
By their numbers in this assay, from the lowest: compounds 4, 2 and 3 (each within the scatter of the next).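

In this assay, going by these compounds alone, the first reading at this position, on a saturated chain carbon bound to an aromatic nitrogen, is a 1.3-fold lower number from compound 3 to compound 4 (0.12 log units; within the scatter) for 2-fluorophenyl in place of 3,4-dichlorophenyl. The two halogen patterns therefore cannot be told apart here, and the aryl group at this place can be exchanged without a step beyond the scatter. No measurement at hand bears on the reason for this result.

On these data alone, whether any group at this place moves the number beyond the scatter remains open. An amine or a carboxylic acid on the benzyl ring would test this, as would a longer chain in place of the benzyl group.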